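From 1H-pyrrol-2-yl to furan-2-yl on the shared core

A few compounds are considered here, and "the series" means these few. Any claim that something is new, unique, unknown or untested is made for them only; others in the source may bear on it.

In a functional assay on MOLT-4 cells (Homo sapiens) for inhibition, read by MTT assay, with a stated time of 48 h (on this read-out higher numbers stand for weaker inhibition and lower numbers for stronger inhibition), compound 1 (`O=C(/C=C/c1ccccc1)c1ccc[nH]1`) shows > 100000 nM as a limit only. Compound 2 (`O=C(/C=C/c1ccc([N+](=O)[O-])cc1)c1ccc[nH]1`) gives 15000 nM and compound 3 (`O=C(/C=C/c1ccc(Br)cc1)c1ccc[nH]1`) gives 49000 nM as measured numbers. The change to compound 4 (`O=C(/C=C/c1ccccc1)c1ccco1`) is furan-2-yl in place of 1H-pyrrol-2-yl on a carbonyl carbon. The nearest evidence is an at least 6.6-fold lower number from compound 1 to compound 2 (0.82 log units; beyond the scatter) and an at least 2.0-fold lower number from compound 1 to compound 3 (0.30 log units; that floor lies within the scatter) (whose floor lies within the scatter), both made on an aromatic carbon and not at this place, so they bear only loosely on the swap. A small drop or none beyond the scatter is therefore expected in this assay here. The estimate means an at least 1.4-fold lower number from compound 1 to compound 4 (0.15 log units; that floor lies within the scatter) as the expected step. For compound 4 the estimated value is 70000 nM within an expected range from 20000 nM to 200000 nM as its upper end.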

Compound 4, half-maximal inhibitory concentration: > 100000 nM
Compound 4 was reported as a limit (the forecaster's own chance of this, stated with the estimate: 45%); at least 1.4-fold (0.15 log units) between middle value and limit.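

Within the data shown here, compound 1 and compound 4 both stand only at a limit in this assay, so no step between them can be read: the limit of > 100000 nM in this assay, at which 2 of the 4 values shown sit.
The compounds shown leave open how furan-2-yl and 1H-pyrrol-2-yl compare on the shared core.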